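Bromo to methoxy at the weak end of the series

The source may report more compounds than this note shows. Statements on the series, on what has been measured and on what is new or still open speak of the compounds shown alone.

In a functional assay on HeLa cells (Homo sapiens) for antiproliferative activity, read by MTT assay (on this read-out higher numbers stand for weaker inhibition and lower numbers for stronger inhibition), compound 3 `Clc1ccc(Nc2nccc(-c3ccc(Br)cc3)n2)cc1` gives 36700 nM, the highest of the three numbers. Compound 2 `COc1ccc(-c2ccnc(Nc3ccc(Cl)cc3Cl)n2)cc1` gives 23000 nM, within the scatter of compound 3. Compound 1 `COc1ccc(-c2ccnc(Nc3ccc([N+](=O)[O-])cc3)n2)cc1` gives 980 nM, well beyond the scatter and lower.

Compound 4 `COc1ccc(-c2ccnc(Nc3ccc(Cl)cc3)n2)cc1` carries one structural change, methoxy in place of bromo on an aromatic carbon. Among the measured compounds shown here, no measured pair isolates this change, so the expectation in this assay is only a modest move toward stronger inhibition, possibly none beyond the scatter. It stays closer to compound 2 at 23000 nM than to compound 1 at 980 nM.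

The estimated step runs a 2.4-fold lower number from compound 3 to compound 4 (0.39 log units; beyond the scatter). The expected value for compound 4 is 15000 nM, within an estimated range of 4000 nM to 40000 nM.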

Compound 4, half-maximal inhibitory concentration: 310 nM
Estimate against measurement, compound 4: 48-fold (1.68 log units) above; measured number outside the range, below it.
By their numbers in this assay, from the lowest: compound 4; then compound 1; then compounds 2 and 3 (each within the scatter of the next).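

Methoxy in place of bromo on an aromatic carbon, para to a large group, gives a large step in this assay (a 120-fold lower number from compound 3 to compound 4 (2.07 log units; beyond the scatter)). Hydrogen in place of chloro on an aromatic carbon is also large (a 74-fold lower number from compound 2 to compound 4 (1.87 log units; beyond the scatter)), whereas chloro in place of nitro on an aromatic carbon is modest (a 3.2-fold lower number from compound 1 to compound 4 (0.50 log units; beyond the scatter)). No measurement shown accounts for these steps.

As far as these compounds go, whether an amine or an ethoxy group in place of methoxy would keep compound 4's number stays open. So does whether the bromo to methoxy step holds alongside nitro rather than chloro.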